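Cytotoxicity on liver cells: acetamido versus amino analogues

The compounds below may be only part of what the source reports. "The series", "measured", "known", "first", "only" and "open" are said of these compounds alone.

Measured compounds:
Compound 1, `COc1cc2cc(NC(C)=O)c(=O)oc2cc1OCCOc1no[n+]([O-])c1S(=O)(=O)c1ccccc1`, gives 10300 nM.
Compound 2, `COc1cc2cc(NC(C)=O)c(=O)oc2cc1OCCCCOc1no[n+]([O-])c1S(=O)(=O)c1ccccc1`, gives 9190 nM.
Compound 3, `COc1cc2cc(N)c(=O)oc2cc1OCCOc1no[n+]([O-])c1S(=O)(=O)c1ccccc1`, gives 9820 nM.

The three compounds were tested in an ADME assay on L02 cells (Homo sapiens) for cytotoxicity, read by MTT assay, with a stated time of 48 h; a lower number here means a stronger inhibitor, a higher number a weaker inhibitor. Compound 1 carries an acetamido group on the aromatic ring; compound 3 shares the core of compound 1 and differs from it only by hydrogen in place of acetyl on a nitrogen on an aromatic ring. That change gave a 1.0-fold lower number from compound 1 to compound 3 (0.02 log units; within the scatter), so the two compounds cannot be told apart in this assay.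

Compound 2 has the longer linker; the difference between the core of compound 1 and the core of compound 2 is not broken down here. The values of compound 1 and compound 2 lie within the scatter of each other, as do those of compound 2 and compound 3.

Compound 4, `COc1cc2cc(N)c(=O)oc2cc1OCCCCOc1no[n+]([O-])c1S(=O)(=O)c1ccccc1`, has not been measured in this assay. It stands to compound 2 as compound 3 stands to compound 1: the difference is hydrogen in place of acetyl on a nitrogen on an aromatic ring, and the place of the change is the same in both pairs, so this is the same change.

Because the step of a 1.0-fold lower number from compound 1 to compound 3 (0.02 log units; within the scatter) stayed within the scatter, the step from compound 2 to compound 4 is expected to be equally small, estimated as a 1.0-fold lower number from compound 2 to compound 4 (0.01 log units; within the scatter). Compound 4 is therefore expected to give about 9000 nM in this assay, most likely between 4500 nM and 18000 nM.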

Compound 4, half-maximal inhibitory concentration: 8630 nM
Beside the measured number, compound 4's estimate is 1.0-fold (0.02 log units) above it, within the range that was stated.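

In this assay, the change from acetamido to amino on the core of compound 2 gave a 1.1-fold lower number from compound 2 to compound 4 (0.03 log units; within the scatter), so the two compounds cannot be told apart in this cytotoxicity read-out on liver cells. Set beside the earlier step on the core of compound 1, the change reads alike on both cores: the same change on two cores in this assay, a 1.0-fold lower number (0.02 log units; within the scatter) from compound 1 to compound 3 and a 1.1-fold lower number (0.03 log units; within the scatter) from compound 2 to compound 4, 1.0-fold (0.01 log units) apart, within the scatter of two such steps

Going by these compounds alone, this shows that, on these two cores, exchanging the acetyl on the nitrogen for hydrogen leaves no step that can be distinguished from the scatter, and that the small step seen on one core was a fair guide to the small step on the other. It does not show that a step of real size would carry over in the same way, since neither core gave one, and two pairs from one series say nothing about cores of a different kind or about any other assay.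

The compounds shown leave open how a benzoyl or a methyl group on that nitrogen would read in this assay, and whether a longer chain than the one in compound 2 would leave the change as small. They also leave open whether the same holds once the phenylsulfonyl group is exchanged for an alkylsulfonyl group such as methylsulfonyl.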